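Fumarate-capped proline hydrazides: expected effect of alkyne side chain

The source may hold more compounds than are shown below. What is called first, only, known or untested is meant among the compounds shown, and "the series" means these compounds.

Measured compounds:
- compound 1, `C/C=C(\NC(C)=O)C(=O)N1CCC[C@H]1C(=O)NN(CC(N)=O)C(=O)/C=C/C(=O)OCC`: 141 nM
- compound 2, `CCOC(=O)/C=C/C(=O)N(CC(N)=O)NC(=O)[C@@H]1CCCN1C(=O)[C@@H]1Cc2ccccc2CN1C(C)=O`: > 1000 nM
- compound 3, `CCOC(=O)C1OC1C(=O)N(CC(N)=O)NC(=O)[C@@H]1CCCN1C(=O)[C@H](CC)NC(C)=O`: 8.1 nM

All numbers come from an assay on isolated protein for inhibition of legumain (Mus musculus), read by fluorescence, with stated times of 30 s and 2.5 h; on this read-out lower numbers stand for stronger inhibition and higher numbers for weaker inhibition. Compound 1 gives 141 nM in this assay, which is the higher of the two numbers obtained. Compound 3 gives 8.1 nM in this assay, the lower number, and the gap between compound 1 and compound 3 lies beyond the scatter. Compound 2 returns only a limit of the assay, > 1000 nM, and no number; one of the three values sits at this limit (the limit of > 1000 nM in this assay, at which 1 of the 3 values shown sits).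

The unmeasured compound 4, `C#CC[C@H](NC(C)=O)C(=O)N1CCC[C@H]1C(=O)NN(CC(N)=O)C(=O)/C=C/C(=O)OCC`, shares the core of compound 1 and differs from it in one place: a group of 8 heavy atoms (6 carbon, 1 nitrogen, 1 oxygen; no ring) in place of a group of 7 heavy atoms (5 carbon, 1 nitrogen, 1 oxygen; no ring), on a carbonyl carbon. Among the measured compounds shown here, no measured pair shows this change, so no step size is available from the data. The expectation is a modest step downward in this assay, not clearly beyond the scatter, from compound 1 to compound 4 of a 1.8-fold lower number from compound 1 to compound 4 (0.25 log units; within the scatter). Compound 4 is therefore estimated at 80 nM, within a range of 25 nM to 300 nM.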

Compound 4, half-maximal inhibitory concentration: 17 nM
The estimate for compound 4 lay 4.7-fold (0.67 log units) above the measured number, outside the stated range (below it).
By their numbers in this assay, from the lowest: compound 3; then compound 4; then compound 1. At a limit, above all of these: compound 2.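

In this assay, among the compounds shown here, the group on the carbonyl carbon whose other neighbours are an amide-type nitrogen in a ring is the first place where a single change can be read: putting the group of 8 heavy atoms, with 1 double bond, 1 triple bond and 1 defined stereocentre, in place of the group of 7 heavy atoms, with 2 double bonds, gives an 8.3-fold lower number from compound 1 to compound 4 (0.92 log units; beyond the scatter). The number at this position therefore moves beyond the scatter with a change of only one heavy atom, while the rest of the core of compound 1, including the fumarate end, stays the same. Nothing measured here gives a cause for this step.

For the compounds shown here, the single step changes the triple bond, the double bonds and the defined stereocentre together, so it cannot assign the drop to any one of them; a saturated propyl chain, a longer chain ending in a triple bond, or a chain ending in an amine would help separate these features. Going by these compounds, whether the step carries over to the end group of compound 3 also stays open, since compound 3 differs from compound 4 in more than one place.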